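Bromo to methoxy on the benzamide ring of the core of compound 3

The source may hold more compounds than are shown below. What is called first, only, known or untested is meant among the compounds shown, and "the series" means these compounds.

Measured so far in a functional assay on SK-BR-3 cells (Homo sapiens) for antiproliferative activity, read by MTT assay, with a stated time of 48 h; a higher number here means a weaker inhibitor, a lower number a stronger inhibitor:
- compound 1 `CCCCCCOc1cc(NC(=O)c2ccc(Br)cc2)ccc1N(C)S(C)(=O)=O`: 39900 nM
- compound 2 `CCCCCCOc1cc(NC(=O)c2ccc(OC)cc2)ccc1N(C)S(C)(=O)=O`: 20000 nM
- compound 3 `COc1ccc(OC)c(COc2cc(NC(=O)c3ccc(Br)cc3)ccc2N(C)S(=O)(=O)C(F)(F)F)c1`: 470 nM

Compound 2 differs from compound 1 by methoxy in place of bromo on an aromatic carbon, and this step gave a 2.0-fold lower number from compound 1 to compound 2 (0.30 log units; within the scatter). Compound 3 carries a different core; how it differs from the core of compound 1 is not broken down here. In this assay compound 3 gives the lowest number of the three.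

Compound 4 `COc1ccc(C(=O)Nc2ccc(N(C)S(=O)(=O)C(F)(F)F)c(OCc3cc(OC)ccc3OC)c2)cc1` is not yet measured. It differs from compound 3 by methoxy in place of bromo on an aromatic carbon, the same change as that from compound 1 to compound 2, at the same place. The expectation for compound 4 rests on that earlier step: because a 2.0-fold lower number from compound 1 to compound 2 (0.30 log units; within the scatter) lay within the scatter, a step of about a 1.6-fold lower number from compound 3 to compound 4 (0.19 log units; within the scatter) is expected here, resting on compound 3 at 470 nM. Compound 4 is therefore estimated at 300 nM, between 100 nM and 1000 nM.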

Compound 4, half-maximal inhibitory concentration: 110 nM
Compound 4: middle estimate off by 2.7-fold (0.44 log units), on the high side, and the stated range covers the measured number.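

In this assay, the change from 4-bromophenyl to 4-methoxyphenyl on the core of compound 3 gave a 4.3-fold lower number from compound 3 to compound 4 (0.63 log units; beyond the scatter). Set beside the same change on the core of compound 1, this step points the same way, and the two steps cannot be told apart: the same change on two cores in this assay, a 2.0-fold lower number (0.30 log units; within the scatter) from compound 1 to compound 2 and a 4.3-fold lower number (0.63 log units; beyond the scatter) from compound 3 to compound 4, 2.1-fold (0.33 log units) apart, within the scatter of two such steps. This is consistent with the change carrying across these two cores, but it rests on one pair per core, the step on the core of compound 1 stays within the scatter, and it shows nothing about any other core.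

Still open, going by these compounds, is how other groups at this place, such as an amine, a carboxylic acid or a nitrile, would compare with bromo and methoxy. Also open, on these data alone, is which part of the difference between the two cores goes with the lower numbers of compound 3 and compound 4.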